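The source may hold more compounds than are shown below. What is called first, only, known or untested is meant among the compounds shown, and "the series" means these compounds.

Working notes on the series, read in a functional assay on HeLa cells (Homo sapiens) for antiproliferative activity, read by MTT assay, with a stated time of 72 h; on this read-out lower numbers stand for stronger inhibition and higher numbers for weaker inhibition. Compound 1 (`C=C(F)C(=O)Nc1cccc(Oc2nc(Nc3ccn(C)n3)nc3c2CSCC3)c1`) gives > 50000 nM, which is a limit of the assay and not a number. Compound 2 (`COc1cccc(Nc2nc3c(c(Oc4cccc(NC(=O)/C=C/C(C)C)c4)n2)CSCC3)c1`) gives > 50000 nM, which is also a limit. Compound 2 therefore has no numerical position, and both values shown stand at the same limit: the limit of > 50000 nM in this assay, at which 2 of the 2 values shown sit. Among the compounds with values here, no order can be read between the two, and no measured step exists.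

Compound 3 (`C=C(F)C(=O)Nc1cccc(Oc2nc(Nc3cccc(OC)c3)nc3c2CSCC3)c1`) keeps the rest of compound 2 and carries 1-fluoroethenyl in place of 3-methylbut-1-en-1-yl on a carbonyl carbon. Compound 1 carries the same 1-fluoroethenyl group and still reads > 50000 nM, again a limit. On that basis, no change beyond the usual scatter is expected in this assay, and any measurable shift is expected towards stronger inhibition. The expected change is a number no higher from compound 2 to compound 3 (the limit leaves the size open). For compound 3 the estimated value is 50000 nM, with an expected range from 15000 nM to 80000 nM, and the reading may well be only a limit again.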

Compound 3, half-maximal inhibitory concentration: 44800 nM
For compound 3 the middle estimate is 1.1-fold (0.05 log units) above the measured one; measured number inside the range.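

In this assay, within the data shown here, compound 3 gives 44800 nM, the first reading that is a number and not a limit, so the change on a carbonyl carbon, 1-fluoroethenyl in place of 3-methylbut-1-en-1-yl, now has a step: an at least 1.1-fold lower number from compound 2 to compound 3 (0.04 log units; that floor lies within the scatter). The same reading gives a second step on a nitrogen on an aromatic ring, 3-methoxyphenyl in place of 1-methyl-1H-pyrazol-3-yl: an at least 1.1-fold lower number from compound 1 to compound 3 (0.04 log units; that floor lies within the scatter). Both steps are floors that lie within the scatter, so neither change is shown to have an effect beyond it, and most of the series still stands at one limit: the limit of > 50000 nM in this assay, at which 2 of the 3 values shown sit.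

From the compounds shown here alone, the true size of both steps stays open, since the readings for compound 1 and compound 2 are limits and give no number to measure from. Also open, going by these compounds, is whether a plain ethenyl or a longer chain on the carbonyl carbon, or a phenyl carrying an amine in place of 3-methoxyphenyl on the nitrogen, would move the reading clearly beyond the scatter.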